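Swapping the aryl group on a nucleoside core

The compounds below may be only part of what the source reports. "The series", "measured", "known", "first", "only" and "open" are said of these compounds alone.

Compound 1, `Cc1cc(-c2ncnc3c2ncn3C2O[C@H](CO)[C@@H](O)[C@H]2O)on1`, gives "not active" (no number reported) in a functional assay on CCRF-CEM cells (Homo sapiens) for inhibition; a higher number here means a weaker inhibitor, a lower number a stronger inhibitor.
Compound 2, `OC[C@H]1OC(n2cnc3c(-c4cc5ccccc5o4)ncnc32)[C@H](O)[C@@H]1O`, gives 15000 nM in this assay.
Compound 3, `OC[C@H]1OC(n2cnc3c(-c4ccc(Cl)cc4)ncnc32)[C@H](O)[C@@H]1O`, gives 900 nM in this assay.

Compound 1 stands apart from the other two measured compounds: for it this assay reports no single number, only that it is not active, so it cannot be placed on the same scale as compound 2 or compound 3. Going by the values given here, the one step measured, a 17-fold lower number from compound 2 to compound 3 (1.22 log units; beyond the scatter), shows that the group on the aromatic carbon of the shared core moves the read-out by a large amount, well beyond the scatter.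

Compound 4, `OC[C@H]1OC(n2cnc3c(-c4ccccn4)ncnc32)[C@H](O)[C@@H]1O`, is compound 1 with pyridin-2-yl in place of 3-methyl-1,2-oxazol-5-yl on an aromatic carbon. This step is not the same as the measured one, but it bears on it in kind: a six-membered aromatic ring enters where a five-membered one leaves, and the six-membered ring of compound 3 gave the lowest number seen. Compound 4 is therefore expected to move from the inactive result of compound 1 toward a measurable number, though without a halogen the value is expected to sit between those of compound 2 and compound 3 rather than match compound 3. Compound 4 is estimated at 8000 nM, within 1500 nM to 50000 nM, with a real chance that only a limit is reported.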

Compound 4, half-maximal inhibitory concentration: 900 nM
Compound 4: the middle estimate sits 8.9-fold (0.95 log units) above what was measured, and the stated range ends above it.
By their numbers in this assay, from the lowest: compounds 3 and 4 (each within the scatter of the next); then compound 2.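

In this assay, the step from 4-chlorophenyl to pyridin-2-yl on an aromatic carbon of the shared core gives no change at the digits printed from compound 3 to compound 4 (within the scatter), so the chlorine is not required for a number of this size, and replacing 1-benzofuran-2-yl with pyridin-2-yl gives a 17-fold lower number from compound 2 to compound 4 (1.22 log units; beyond the scatter). Going by these compounds alone, compound 1, with 3-methyl-1,2-oxazol-5-yl at the same place, gives "not active" (no number reported), so the step from it to compound 4 cannot be read as a size, and the data show only that this exchange of one aromatic ring for another separates a compound without a number from one with a number. Nothing measured here accounts for these differences in the read-out.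

The compounds shown leave open whether a plain phenyl, carrying neither chlorine nor a ring nitrogen, would read like compound 3 and compound 4, and whether pyridin-3-yl or pyridin-4-yl would keep the value of pyridin-2-yl. They also leave open how an amine or a carboxylic acid on the pyridine ring of compound 4 would change the number in this assay.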